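Growth inhibition notes: from compound 2 to compound 3

This account rests on a few compounds, and the source may have more. Where it says the series, first, only, none or still open, it means among the compounds named here.

Within the data shown here, in a functional assay on L929 cells (Mus musculus) for inhibition (a higher number here means a weaker inhibitor of growth, a lower number a stronger inhibitor of growth), compound 2 `NNCc1cc(O)n2nc(N)c([N+](=O)[O-])c2n1` gives 35.2 ug/mL, the only actual number available in this small set. Compound 1 `Nc1nn2c(O)cc(-c3cc([N+](=O)[O-])c(Cl)cc3Cl)nc2c1[N+](=O)[O-]` gives > 50 ug/mL, which is a limit of the assay and not a number. Among the measured compounds shown here, no two measured compounds differ in one place, so no measured step is available to size the next change.

Compound 3 `CCSC(N)NCc1cc(O)n2nc(N)c([N+](=O)[O-])c2n1` carries amino(ethylsulfanyl)methyl in place of amino on an amine nitrogen. The core of compound 2 is kept. With compound 2 at 35.2 ug/mL as the sole anchor, no direction can be argued from the data. The expected change, a 1.2-fold lower number from compound 2 to compound 3 (0.07 log units; within the scatter), is none beyond the usual scatter. Compound 3 is estimated at 30 ug/mL in this assay, with an expected range of 12 ug/mL to 60 ug/mL.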

Compound 3, concentration for 50% growth inhibition: > 50 ug/mL
Compound 3 was reported as a limit (the forecaster's own chance of this, stated with the estimate: 30%); at least 1.6-fold (0.22 log units) between middle value and limit.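

In this assay compound 3 gives > 50 ug/mL, which is a limit of the assay and not a number. Among these compounds, the only one-place step in the set reads an at least 1.4-fold higher number from compound 2 to compound 3 (0.15 log units; that floor lies within the scatter), with amino(ethylsulfanyl)methyl in place of amino on an amine nitrogen; at this position the larger group brings no lower number, while the limit leaves unfixed whether the true gap exceeds the scatter. The step is therefore a floor and not a size, and the series now sits largely at the same ceiling: the limit of > 50 ug/mL in this assay, at which 2 of the 3 values shown sit.

Going by these compounds, it remains open whether any replacement on this amine nitrogen can lower the number, for instance a methylsulfanyl group, a longer chain on the sulfur, or a carboxylic acid. Also open, on these data alone, is how far compound 3 actually lies from compound 2, since only one of the two has a measured number.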